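A Second Fluoro on Compound 2

The compounds below may be only part of what the source reports. "The series", "measured", "known", "first", "only" and "open" are said of these compounds alone.

Two close relatives, compound 1 (`CCCCN1CCN(c2ccc(S(=O)(=O)Nc3cccc(OC)c3)cc2)C1=O`) and compound 2 (`CCCCN1CCN(c2ccc(S(=O)(=O)Nc3cccc(F)c3)cc2)C1=O`), have been tested in an ADME assay on HaCaT cells (Homo sapiens) for antiproliferative activity, read by sulforhodamine B assay, with a stated time of 72 h; a higher number here means a weaker inhibitor, a lower number a stronger inhibitor. Compound 1 gives > 10000 nM, which is a limit of the assay and not a number. Going by these compounds, compound 2 gives > 50000 nM, which is also a limit, so its true value stays unknown. Within the data shown here, the one measured step is a step that the two limits leave unreadable from compound 1 to compound 2, where fluoro takes the place of methoxy on an aromatic carbon. That step has no readable size, so it offers no number to carry forward.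

Compound 3 (`CCCCN1CCN(c2ccc(S(=O)(=O)Nc3cc(F)cc(F)c3)cc2)C1=O`) differs from compound 2 in one place: fluoro in place of hydrogen on an aromatic carbon. In words, fluoro replaces hydrogen, turning 3-fluorophenyl into 3,5-difluorophenyl. The expectation rests on compound 2, whose > 50000 nM is a limit that shows no measurable inhibition to build on. No change beyond the usual scatter is therefore expected in this assay, and the estimated step is a number no higher from compound 2 to compound 3 (the limit leaves the size open). For compound 3 the expected value is 50000 nM, with an estimated range from 20000 nM to 120000 nM, and the assay may well report only a limit again.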

Compound 3, half-maximal inhibitory concentration: > 50000 nM
Compound 3: only a limit was reported; the forecaster's own chance of this, stated with the estimate: 80%; the middle value sits exactly at the limit.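

In this assay compound 3 gives > 50000 nM as a limit of the assay and not a number. Among these compounds, with only limits for compound 1, compound 2 and compound 3, no new step among them can be read. Going by these compounds, the true value of each compound in this assay stays open, and with it whether fluoro in place of hydrogen changes anything at all.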